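Swapping a urea substituent on a chloro-bearing core

This account rests on a few compounds, and the source may have more. Where it says the series, first, only, none or still open, it means among the compounds named here.

Three compounds share a core and were tested in a functional assay on A549 cells (Homo sapiens) for antiproliferative activity, read by MTT assay, with a stated time of 72 h; on this read-out higher numbers stand for weaker inhibition and lower numbers for stronger inhibition. Compound 1 `CCN(CC)CCNC(=O)Nc1nc2ccc(-c3cnc(OC)c(NS(=O)(=O)c4ccc(F)cc4)c3)cc2s1` gives 450 nM; compound 2 `COc1ncc(-c2ccc3nc(NC(=O)NC4CC4)sc3c2)cc1NS(=O)(=O)c1ccc(F)cc1` gives 900 nM; compound 3 `O=C(Nc1nc2ccc(-c3cnc(Cl)c(NS(=O)(=O)c4ccc(F)cc4)c3)cc2s1)NC1CC1` gives 1030 nM. Compound 1 differs from compound 2 by 2-(diethylamino)ethyl in place of cyclopropyl on an amide-type nitrogen, and that change gave a 2.0-fold lower number from compound 2 to compound 1 (0.30 log units; within the scatter). Compound 3 differs from compound 2 by chloro in place of methoxy on an aromatic carbon, a change that gave a 1.1-fold higher number from compound 2 to compound 3 (0.06 log units; within the scatter). Compound 4 `CCN(CC)CCNC(=O)Nc1nc2ccc(-c3cnc(Cl)c(NS(=O)(=O)c4ccc(F)cc4)c3)cc2s1` is not yet measured; it differs from compound 3 by 2-(diethylamino)ethyl in place of cyclopropyl on an amide-type nitrogen, the same change as from compound 2 to compound 1, made on the core of compound 3. Because the earlier step was a 2.0-fold lower number from compound 2 to compound 1 (0.30 log units; within the scatter), a step of similar size is expected here, so compound 4 is estimated to give a 2.0-fold lower number from compound 3 to compound 4 (0.30 log units; within the scatter) in this assay. Compound 4 is expected to reach about 520 nM, between 250 nM and 1100 nM.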

Compound 4, half-maximal inhibitory concentration: 5260 nM
Beside the measured number, compound 4's estimate is 10-fold (1.00 log units) below it; measured number above the stated range.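

In this assay, the swap of cyclopropyl for 2-(diethylamino)ethyl did not carry over from one core to the other: on the chloro-bearing core it gave a 5.1-fold higher number from compound 3 to compound 4 (0.71 log units; beyond the scatter), and the two steps for this change disagree: the same change on two cores in this assay, a 2.0-fold lower number (0.30 log units; within the scatter) from compound 2 to compound 1 and a 5.1-fold higher number (0.71 log units; beyond the scatter) from compound 3 to compound 4, 10-fold (1.01 log units) apart, beyond the scatter of two such steps

Chloro in place of methoxy also depends on the group on the amide-type nitrogen, giving a 12-fold higher number from compound 1 to compound 4 (1.07 log units; beyond the scatter), and its two steps disagree as well: the same change on two cores in this assay, a 1.1-fold higher number (0.06 log units; within the scatter) from compound 2 to compound 3 and a 12-fold higher number (1.07 log units; beyond the scatter) from compound 1 to compound 4, 10-fold (1.01 log units) apart, beyond the scatter of two such steps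

So the two changes do not act independently in these four compounds, but one such set cannot show why, or whether this holds for other groups.

Going by these compounds, it remains open whether a 2-(dimethylamino)ethyl chain or a chain ending in a hydroxyl would behave like 2-(diethylamino)ethyl on the chloro-bearing core. On these data alone, it is equally open whether a fluoro or a methyl in place of chloro would give a step of this size.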